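The source may hold more compounds than are shown below. What is called first, only, known or untested is meant among the compounds shown, and "the series" means these compounds.

In a physicochemical assay for solubility, read by nephelometry, at pH 7.4 (on this read-out lower numbers stand for lower solubility and higher numbers for higher solubility), compound 2 (`COc1cccc(NC(=O)c2nnn(CC3CCNCC3)c2N)c1`) gives > 250000 nM as a limit of the assay and not a number. Compound 1 (`COc1cccc(NC(=O)c2nnn(Cc3ccncc3)c2N)c1`) gives < 12000 nM which is also a limit. Compound 3 (`COc1cccc(NC(=O)c2nnn(Cc3ccc(C(C)C)cc3)c2N)c1`) carries 4-isopropylphenyl in place of piperidin-4-yl on a saturated chain carbon bound to an aromatic nitrogen. For the measured compounds named here, one measured step bears on this change, the large step that brought in the piperidin-4-yl (an at least 20-fold higher number from compound 1 to compound 2 (1.31 log units; beyond the scatter)). Its reverse is taken as the guide, so the estimated step in this assay is large and downward (an at least 31-fold lower number from compound 2 to compound 3 (1.49 log units; beyond the scatter)). The estimated value for compound 3 is 8000 nM with an expected range from 2000 nM to 25000 nM in this assay.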

Compound 3, solubility: 14000 nM
Beside the measured number, compound 3's estimate is 1.8-fold (0.24 log units) below it; low and high end bracket the measured number.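

In this assay, replacing piperidin-4-yl with 4-isopropylphenyl gives an at least 17-fold lower number from compound 2 to compound 3 (1.25 log units; beyond the scatter). Replacing pyridin-4-yl with the same group gives an at least 1.1-fold higher number from compound 1 to compound 3 (0.06 log units; that floor lies within the scatter), so this step does not separate compound 3 from compound 1. Both steps rest on a limit of the assay, and compound 3 is the only one of the three to give a number at this position, while the high reading stays with the piperidin-4-yl of compound 2.

As far as these compounds go, it remains open whether that reading follows the ring nitrogen or the saturated ring. A cyclohexyl group in the same place would bear on this.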